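The source may report more compounds than this note shows. Statements on the series, on what has been measured and on what is new or still open speak of the compounds shown alone.

Of the compounds shown here, two from this series have so far been measured in a functional assay on the whole organism (strain albino) for inhibition, with Rattus norvegicus as the target, read by paw edema, with stated times of 1 h and 3 h, at a dose of 100 mg/kg by the oral route; a lower number here means a weaker effect, a higher number a stronger effect of the compound at the dose given. Compound 1 `N#Cc1c(Nc2ccc(Cl)cc2)nc(SCC(=O)Nn2c(COc3ccc(Cl)cc3Cl)nc3ccccc3c2=O)nc1-c1ccccc1` gives 59.7% in this assay, whereas compound 2 `N#Cc1c(Nc2ccccc2)nc(SCC(=O)Nn2c(COc3ccc(Cl)cc3Cl)nc3ccccc3c2=O)nc1-c1ccc(O)cc1` gives 91.2%. Compound 2 therefore stands highest of the two numbers, and its nearest neighbour, compound 1, lies below it by a gap that goes beyond the usual scatter. Compound 1 and compound 2 differ from each other in two places at once, so their two values alone cannot be split into separate contributions.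

Compound 3 `N#Cc1c(Nc2ccc(Cl)cc2)nc(SCC(=O)Nn2c(COc3ccc(Cl)cc3Cl)nc3ccccc3c2=O)nc1-c1ccc(O)cc1` has not yet been measured in this assay. It differs from compound 2 in one place only: chloro in place of hydrogen on an aromatic carbon The same change, cut one bond further out, reads phenyl to 4-chlorophenyl, or anilino to (4-chlorophenyl)amino. Some weakening is expected because compound 1 gives 59.7% while carrying this same (4-chlorophenyl)amino group, although compound 1 also differs from compound 2 elsewhere. A moderate downward step is expected, a number 13.2 percentage points lower from compound 2 to compound 3 (beyond the scatter), one that may still fall within the scatter. Compound 3 is estimated at 78% in this assay, with a likely range from 60% to 95%.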

Compound 3, a percentage reported as inhibition, in the whole organism at one dose (the size of the read-out at that dose, not a potency): 79%
Estimate against measurement, compound 3: 1 percentage points below, and the stated range covers the measured number.
By their numbers in this assay, from the lowest: compound 1; then compound 3; then compound 2.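

Compound 3 divides the gap that compound 1 and compound 2 left undivided, as it differs from each of them in one place only. In this assay, chloro in place of hydrogen on an aromatic carbon, para to a large group, gives a number 12.2 percentage points lower from compound 2 to compound 3 (beyond the scatter), while adding a hydroxy group gives a number 19.3 percentage points higher from compound 1 to compound 3 (beyond the scatter), so each change registers on its own and neither alone accounts for the whole difference between the two earlier compounds. Nothing available explains why either step occurs.

The compounds shown leave open whether the lower reading belongs to chloro in particular or would also appear with fluoro, methyl or methoxy at the same place on the anilino ring, and whether an amine or a carboxylic acid in place of the hydroxy group would keep the higher reading. They also leave open whether these two steps would keep their direction and size at another dose or with the rest of the shared core changed.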